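Trading a Sulfanyl Link for an Amino Link

The source may report more compounds than this note shows. Statements on the series, on what has been measured and on what is new or still open speak of the compounds shown alone.

Three compounds share one core. Compound 1 `CC(=O)OCc1ccc2oc(=O)c(C(=O)Oc3cccc(Br)c3)cc2c1` gives 21.8% in a functional assay on HT-1080 cells (Homo sapiens), read by transwell migration, with a stated time of 24 h, tested at 1 uM; a higher number here means a weaker effect of the compound at the concentration tested, a lower number a stronger effect. Compound 2 `CC(=O)OCc1ccc2oc(=O)c(C(=O)Sc3ccccc3)cc2c1` gives 83.5%, and compound 3 `CC(=O)OCc1ccc2oc(=O)c(C(=O)Sc3cccc(Cl)c3)cc2c1` gives 65.8%. Compound 3 thus stands second highest of the three: the move a number 44 percentage points higher from compound 1 to compound 3 (beyond the scatter) is large, while a number 17.7 percentage points lower from compound 2 to compound 3 (beyond the scatter) is modest. Compound 4 `CC(=O)OCc1ccc2oc(=O)c(C(=O)N(C)c3ccccc3Cl)cc2c1` carries (2-chlorophenyl)(methyl)amino in place of (3-chlorophenyl)sulfanyl on a carbonyl carbon. Within the data shown here, no measured step bears directly on this change: both steps from compound 1 concern a sulfanyl group replacing a phenoxy group, and the step from compound 2 to compound 3 concerns a chloro substituent alone. On that thin footing, compound 4 is expected near 60% in this assay, within 30% to 90%. That estimate means a step of a number 5.8 percentage points lower from compound 3 to compound 4 (within the scatter), not expected to reach beyond the scatter.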

Compound 4, a percentage reported as activity, at one concentration (the size of the read-out at that concentration, not a potency): 62.8%
Beside the measured number, compound 4's estimate is 2.8 percentage points below it, within the range that was stated.
By their numbers in this assay, from the lowest: compound 1; then compounds 4 and 3 (each within the scatter of the next); then compound 2.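

In this assay the amino link shows a number 3 percentage points lower from compound 3 to compound 4 (within the scatter) and so reads level with the sulfanyl link, although this change also moves the chlorine and adds the methyl. The amino compound still shares the sulfanyl compounds' distance from the 3-bromophenoxy ester, with a number 41 percentage points higher from compound 1 to compound 4 (beyond the scatter) against a number 20.7 percentage points lower from compound 2 to compound 4 (beyond the scatter) on the other side. No available evidence explains these steps. Going by these compounds, whether the link, the chlorine placement or the methyl governs this reading stays open. So does how a piperidine amide or a carboxylic acid would read on this carbonyl carbon.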